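The source may hold more compounds than are shown below. What is called first, only, known or untested is meant among the compounds shown, and "the series" means these compounds.

In a functional assay for agonist activity at G protein-coupled receptor 88 (Homo sapiens), read by HTRF and cAMP accumulation (on this read-out lower numbers stand for an effect already at smaller amounts and higher numbers for an effect only at larger amounts of compound), compound 2, with the structure `CC[C@H](C)[C@H](N)CN(C(=O)[C@@H]1C[C@H]1c1ccccn1)c1ccc(-c2ccccc2)cc1`, gives 130 nM, the only number shown for it alongside a further entry without a single value. Compound 1, the structure `CC[C@H](C)[C@H](N)CN(C(=O)[C@@H]1C[C@H]1c1ccccc1)c1ccc(-c2ccccc2)cc1`, has been measured more than once in this assay and gives 230 nM; 800 nM (2 entries); the spread between those entries, (the several entries of compound 1 in this assay, 230 nM; 800 nM (2 entries)), shows how far repeated measurements of one compound can lie apart here. Compound 3, the structure `CC[C@H](C)[C@H](N)CN(C(=O)[C@@H]1C[C@H]1c1cccnc1)c1ccc(-c2ccccc2)cc1`, has not yet been measured in this assay. It differs from compound 2 in one place: pyridin-3-yl in place of pyridin-2-yl on a saturated ring carbon. Among the compounds with values here, no measured pair shows this change, so the size of the step is open. The expectation is that the step of a 1.9-fold higher number from compound 2 to compound 3 (0.28 log units; within the scatter) stays small, within the scatter or a modest loss. Compound 3 is therefore expected to give about 250 nM, somewhere between 80 nM and 800 nM.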

Compound 3, half-maximal effective concentration: 1500 nM
Compound 3: the middle estimate sits 6.0-fold (0.78 log units) below what was measured; the whole stated range lies below it.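

With the same atoms and the same counts of donors and acceptors on both groups, the change from pyridin-2-yl to pyridin-3-yl on the cyclopropane carbon gives a 12-fold higher number from compound 2 to compound 3 (1.06 log units; beyond the scatter) in this assay. This shows that the position is sensitive to where the nitrogen sits in the aromatic ring, which compound 1 and compound 2 alone could not show. The step is also wider than the gap between repeated measurements of a single compound: the several entries of compound 1 in this assay, 230 nM; 800 nM (2 entries).

The compounds shown do not say what lies behind this loss, or whether pyridin-4-yl would read closer to compound 2 or to compound 3. From the compounds shown here alone, it also remains open whether an added methoxy or amine group on the pyridin-2-yl ring would be tolerated at this position.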